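Fluoro for chloro on the 3-halophenyl sulfone

The compounds below may be only part of what the source reports. "The series", "measured", "known", "first", "only" and "open" are said of these compounds alone.

Measured compounds in an assay on HeLa cells for displacement of a labelled ligand from 5-hydroxytryptamine receptor 6 (Homo sapiens); on this read-out higher numbers stand for weaker inhibition and lower numbers for stronger inhibition:
compound 1 `O=S(=O)(c1cccc(F)c1)c1cn(C2CCNC2)c2ncccc12` — 2.7 nM
compound 2 `CCN1CCC(n2cc(S(=O)(=O)c3cccc(Cl)c3)c3cccnc32)C1` — 3.3 nM
compound 3 `O=S(=O)(c1cccc(Cl)c1)c1cn(C2CCCNC2)c2ncccc12` — 1.3 nM

Compound 3 gives the lowest number of the three in this assay, and its distance to each of the others is beyond the scatter: compound 1 sits higher, compound 2 higher still. Going by the values given here, the one single-point step among the measured compounds, a 2.5-fold lower number from compound 2 to compound 3 (0.40 log units; beyond the scatter), concerns the group on the aromatic nitrogen, not the halogen on the phenyl ring.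

Compound 4 `O=S(=O)(c1cccc(F)c1)c1cn(C2CCCNC2)c2ncccc12` differs from compound 3 only by fluoro in place of chloro on an aromatic carbon. Among the compounds with values here, no measured pair isolates this fluoro-for-chloro exchange: compound 1 carries fluoro and compound 3 carries chloro, but they also differ in the ring on the aromatic nitrogen, so their values show only that both are low numbers in this assay. A one-atom halogen swap of this kind is not expected to move the read-out far. The expected step is a 1.5-fold higher number from compound 3 to compound 4 (0.16 log units; within the scatter), a small rise in the number that may well fall within the scatter. Compound 4 is therefore estimated at 1.9 nM, within a range from 0.8 nM to 4.5 nM.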

Compound 4, inhibition constant: 2.4 nM
The estimate for compound 4 lay 1.3-fold (0.10 log units) below the measured number, within the range that was stated.
By their numbers in this assay, from the lowest: compounds 3, 4, 1 and 2 (each within the scatter of the next, the first and the last beyond it).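

In this assay, the exchange of 3-chlorophenyl for 3-fluorophenyl can now be read on its own, and a 1.8-fold higher number from compound 3 to compound 4 (0.27 log units; within the scatter) leaves the two halogens unseparated at this place on the ring. The new compound also gives a second single-point reading, this time on the aromatic nitrogen: with 3-fluorophenyl held constant, a 1.1-fold lower number from compound 1 to compound 4 (0.05 log units; within the scatter), so piperidin-3-yl and pyrrolidin-3-yl are not separated either, a reading that the earlier step, in which the ethyl group also changes, could not give. Nothing at hand bears on why either exchange stays within the scatter.

The compounds shown leave open how this place on the ring responds to groups other than a halogen, such as methoxy, trifluoromethyl or nitrile, and whether a larger group would move the number beyond the scatter. They also leave open what the ethyl group of 1-ethylpyrrolidin-3-yl does on its own, as the pairs shown do not set it against pyrrolidin-3-yl with the same halogen on the phenyl ring.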